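Removal of the carbamoyl group: compound 3 to compound 4

The compounds below may be only part of what the source reports. "The series", "measured", "known", "first", "only" and "open" are said of these compounds alone.

Compound 3, `COc1ccc(S(=O)(=O)N2CCc3cccc(NC(=O)N(C)c4ccccc4)c32)cc1`, sits at the limit of a functional assay on KB cells (Homo sapiens) for cytotoxicity (on this read-out higher numbers stand for weaker inhibition and lower numbers for stronger inhibition), where it gives > 10000 nM, a limit and not a number. Compound 3 is one of the values that sit at the limit of > 10000 nM in this assay, at which 1 of the 3 values shown sits. Compound 4, `COc1ccc(S(=O)(=O)N2CCc3cccc(N)c32)cc1`, differs from compound 3 by hydrogen in place of methyl(phenyl)carbamoyl on a nitrogen on an aromatic ring.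

The measured steps all keep the carbonyl carbon and change the group on it. In this assay compound 1, `COc1ccc(C(=O)Nc2cccc3c2N(S(=O)(=O)c2ccc(OC)cc2)CC3)cc1`, gives 2600 nM. Compound 2, `COc1ccc(S(=O)(=O)N2CCc3cccc(NC(=O)c4ccco4)c32)cc1`, gives 9.6 nM in this assay. The step of a 270-fold lower number from compound 1 to compound 2 (2.43 log units; beyond the scatter) and the step of an at least 1000-fold higher number from compound 2 to compound 3 (3.01 log units; beyond the scatter) are both large, and the step of an at least 3.8-fold higher number from compound 1 to compound 3 (0.58 log units; beyond the scatter) is at least modest. None of them removes the whole group on the ring nitrogen, so none bears directly on the step to compound 4. The steps show that large swings follow small changes on the carbonyl carbon, and compound 3 already lies at the limit.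

Compound 4 is expected to remain weak in this assay, around 20000 nM. For compound 4 the expected range runs from 3000 nM to 100000 nM. The step that the limit leaves unreadable from compound 3 to compound 4 is therefore expected to be small or unresolved at the limit.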

Compound 4, half-maximal inhibitory concentration: 2800 nM
Estimate against measurement, compound 4: 7.1-fold (0.85 log units) above, outside the stated range (below it).
By their numbers in this assay, from the lowest: compound 2; then compounds 1 and 4 (each within the scatter of the next). At a limit, above all of these: compound 3.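

In this assay compound 3 gives > 10000 nM, which is a limit and not a number, so the step to hydrogen on this nitrogen, an at least 3.5-fold lower number from compound 3 to compound 4 (0.55 log units; beyond the scatter), is known from one side only: the limit of > 10000 nM in this assay, at which 1 of the 4 values shown sits.

With hydrogen as the baseline, a 1.1-fold higher number from compound 1 to compound 4 (0.03 log units; within the scatter) shows that (4-methoxyphenyl)carbonyl on this nitrogen leaves the read-out unchanged, while a 290-fold higher number from compound 2 to compound 4 (2.46 log units; beyond the scatter) ties the low number of compound 2 to (furan-2-yl)carbonyl. Of the three groups, only (furan-2-yl)carbonyl gives a lower number than hydrogen, and methyl(phenyl)carbamoyl goes the other way, so a carbonyl on this nitrogen does not by itself lower the number.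

As far as these compounds go, it stays open whether (thiophen-2-yl)carbonyl or a small acetyl on the same nitrogen would keep the low number of compound 2. From the compounds shown here alone, how far the number of compound 3 lies past its limit also stays open.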